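A few compounds are considered here, and "the series" means these few. Any claim that something is new, unique, unknown or untested is made for them only; others in the source may bear on it.

Measured so far:
compound 1, `CC(C)CN(NC(=O)OCc1ccccc1)C(=O)CN(Cc1ccccc1)NC(=O)CBr`, 1300 nM
compound 2, `CC(C)CN(CC(=O)NN(Cc1ccccc1)c1cnccn1)NC(=O)CBr`, 24100 nM
compound 3, `CC(C)CN(NC(=O)OCc1ccccc1)C(=O)CN(Cc1ccccc1)NC(=O)Cc1cccc(Br)c1`, 30000 nM

All three were tested in a functional assay on L1210 cells (Mus musculus) for inhibition; a lower number here means a stronger inhibitor, a higher number a weaker inhibitor. Compound 1 and compound 3 share a core and differ in one place, (3-bromophenyl in place of bromo on a saturated chain carbon bound to a carbonyl carbon), and this change gave a 23-fold higher number from compound 1 to compound 3 (1.36 log units; beyond the scatter). Compound 2 carries a different core; how its core differs from that of compound 1 is not broken down here. Its value stands near that of compound 3 and well apart from that of compound 1.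

Compound 4, `CC(C)CN(CC(=O)NN(Cc1ccccc1)c1cnccn1)NC(=O)Cc1cccc(Br)c1`, has not yet been tested in this assay. It is related to compound 2 by 3-bromophenyl in place of bromo on a saturated chain carbon bound to a carbonyl carbon, the same change, at the same place, that separates compound 1 from compound 3. Since that change on the first core produced a 23-fold higher number from compound 1 to compound 3 (1.36 log units; beyond the scatter), a step of similar size and direction is expected on the second core, so that from compound 2 to compound 4 the estimate is a 12-fold higher number from compound 2 to compound 4 (1.10 log units; beyond the scatter). Compound 4 is thus expected to give about 300000 nM in this assay, with a real chance that the assay reports only a limit.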

Compound 4, half-maximal inhibitory concentration: 45000 nM
Compound 4: the middle estimate sits 6.7-fold (0.82 log units) above what was measured, outside the stated range (below it).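

In this assay, putting 3-bromophenyl in place of bromo on a saturated chain carbon bound to a carbonyl carbon gave a 1.9-fold higher number from compound 2 to compound 4 (0.27 log units; within the scatter), so the large step seen on the core of compound 1 did not carry over in size to the core of compound 2: the same change on two cores in this assay, a 23-fold higher number (1.36 log units; beyond the scatter) from compound 1 to compound 3 and a 1.9-fold higher number (0.27 log units; within the scatter) from compound 2 to compound 4, 12-fold (1.09 log units) apart, beyond the scatter of two such steps. On the second core the step lies within the scatter, so the direction seen on the first core is not confirmed there either. Two pairs show only that the size of this change depends on the core in these compounds; they do not show why, nor how the change would behave on any further core.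

The compounds shown hold only bromo and 3-bromophenyl at this place, so how a chloro group or an amine there would read in this assay on either core stays open. Also open, on these data alone, is whether a third core would follow the pair compound 1 and compound 3 or the pair compound 2 and compound 4.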